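A Methoxy Replaces Fluorine on the Amide Aryl Ring

The source may hold more compounds than are shown below. What is called first, only, known or untested is meant among the compounds shown, and "the series" means these compounds.

Compound 2 `O=C(Nc1cccc(-c2oc3cc(-c4ccc(F)cc4)ccc3c(=O)c2O)c1)c1ccc(F)cc1` sits at the upper end of the two numbers measured in a functional assay on A549 cells (Homo sapiens) for antiproliferative activity, read by CCK-8 assay, with a stated time of 72 h (a lower number here means a stronger inhibitor, a higher number a weaker inhibitor), where compound 2 gives 6930 nM. For the measured compounds named here, its only neighbour, compound 1 `O=C(Nc1cccc(-c2oc3cc(-c4ccc(F)cc4)ccc3c(=O)c2O)c1)c1ccccc1F`, gives 4410 nM in this assay. Going by the values given here, the single measured step, a 1.6-fold higher number from compound 1 to compound 2 (0.20 log units; within the scatter), moves a fluorine to another position on the ring attached to the carbonyl and stays within the scatter, so the two numbers cannot be put in order.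

Compound 3 `COc1ccc(C(=O)Nc2cccc(-c3oc4cc(-c5ccc(F)cc5)ccc4c(=O)c3O)c2)cc1` carries the change (methoxy in place of fluoro on an aromatic carbon). Among the compounds with values here, no measured step shows this exchange; the only step seen concerns a shift of fluorine on the same ring and lies within the scatter. Nothing here points to a shift beyond the scatter in this assay. Compound 3 is therefore estimated at 6000 nM, with a range from 2500 nM to 15000 nM, an expected step of a 1.2-fold lower number from compound 2 to compound 3 (0.06 log units; within the scatter).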

Compound 3, half-maximal inhibitory concentration: 8700 nM
Compound 3: middle estimate off by 1.5-fold (0.16 log units), on the low side; measured number inside the range.
By their numbers in this assay, from the lowest: compounds 1, 2 and 3 (each within the scatter of the next).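

Swapping fluoro for methoxy on the aromatic carbon para to a large group brings an oxygen into the molecule, yet in this assay it gives a 1.3-fold higher number from compound 2 to compound 3 (0.10 log units; within the scatter), so this position accepts both groups without a readable difference. Comparing 4-methoxyphenyl with 2-fluorophenyl on the carbonyl carbon gives a 2.0-fold higher number from compound 1 to compound 3 (0.30 log units; within the scatter), which means that the three compounds, with changes in both the group and its place on the ring, cannot be put in order. No measurement on these compounds offers an explanation for these numbers.

On these data alone, an amine, a carboxylic acid or a longer chain at this position might still move the number beyond the scatter, and that remains open. As far as these compounds go, all three compounds also share the same core, so the effect of changes there is unknown.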